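The source may report more compounds than this note shows. Statements on the series, on what has been measured and on what is new or still open speak of the compounds shown alone.

Measured so far:
compound 1, `CC(=O)Oc1ccc(-c2ccc(F)cc2F)cc1C(=O)O`, 0%;
compound 2, `O=C(Oc1ccc(-c2ccc(F)cc2F)cc1C(=O)O)c1ccccc1`, 7.97%;
compound 3, `CC(=O)Oc1ccc(-c2ccc(F)cc2F)cc1C(=O)NCc1ccccc1`, 16.6%.

In a functional assay on the whole organism (strain Kunming) for inhibition, with Mus musculus as the target, in the writhing test, at a dose of 40 mg/kg by the oral route (a higher number here means more inhibition at the dose given (going by the name of the read-out), a lower number less inhibition), compound 1 gives no inhibition, and the other two measured compounds stay close to it. Compound 2, with a phenyl in place of methyl on a carbonyl carbon, gives a number 8 percentage points higher from compound 1 to compound 2 (within the scatter), a number that lies within the scatter of both compound 1 and compound 3. Compound 3, with benzylamino in place of hydroxy on a carbonyl carbon, gives a number 16.6 percentage points higher from compound 1 to compound 3 (beyond the scatter).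

The unmeasured compound 4 is `Cc1ccccc1NC(=O)c1cc(-c2ccc(F)cc2F)ccc1OC(=O)c1ccccc1`. It differs from compound 2 by (2-methylphenyl)amino in place of hydroxy on a carbonyl carbon. For the measured compounds named here, the one measured step that bears on this is the amide for acid exchange from compound 1 to compound 3, which gave a modest rise beyond the scatter. A change of the same kind from compound 2 is therefore expected to move this assay upward by a similar modest amount. The expected step is a number 14 percentage points higher from compound 2 to compound 4 (beyond the scatter). Compound 4 is estimated to give 22%, between 5% and 40%.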

Compound 4, a percentage reported as inhibition, in the whole organism at one dose (the size of the read-out at that dose, not a potency): 20.8%
Compound 4: middle estimate off by 1.2 percentage points, on the high side; low and high end bracket the measured number.
By their numbers in this assay, from the lowest: compounds 1, 2, 3 and 4 (each within the scatter of the next, the first and the last beyond it).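

In this assay, (2-methylphenyl)amino in place of hydroxy on the carbonyl carbon gives a number 12.8 percentage points higher from compound 2 to compound 4 (beyond the scatter). The rise on turning the acid into an amide therefore appears with phenyl on the other carbonyl carbon as well as with methyl, where benzylamino gave a number 16.6 percentage points higher from compound 1 to compound 3 (beyond the scatter), so it is not confined to one amine or one ester among these compounds. Nothing measured here bears on why the amides give more inhibition.

For the compounds shown here, the effect of the amine itself remains unresolved, as no two compounds differ only in benzylamino against (2-methylphenyl)amino. Also open, going by these compounds, is how an unsubstituted phenylamino, a morpholine or a longer alkyl chain on the amide nitrogen would fare at this position.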